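From an Amino Chain to a Benzyl Amide

The source may hold more compounds than are shown below. What is called first, only, known or untested is meant among the compounds shown, and "the series" means these compounds.

Measured compounds:
compound 1, `NCCNC(=O)Cn1nc(N)c2c(C(F)(F)F)cc(-c3ccccc3)nc21`: 50200 nM
compound 2, `Nc1nn(CC(=O)NCCO)c2nc(-c3ccccc3)cc(C(F)(F)F)c12`: 128000 nM

In a functional assay on A549 cells (Homo sapiens) for cytotoxicity, read by MTT assay, with a stated time of 24 h (on this read-out higher numbers stand for weaker inhibition and lower numbers for stronger inhibition), compound 1 gives the lower of the two numbers, with compound 2 standing apart by a 2.5-fold higher number from compound 1 to compound 2 (0.41 log units; beyond the scatter). Compound 3, `Nc1nn(CC(=O)NCc2ccccc2)c2nc(-c3ccccc3)cc(C(F)(F)F)c12`, differs from compound 1 by phenyl in place of aminomethyl on a saturated chain carbon bound to an amide-type nitrogen. Within the data shown here, the only step that bears on this change is the one from compound 1 to compound 2, where the amino end was exchanged and the number rose by a 2.5-fold higher number from compound 1 to compound 2 (0.41 log units; beyond the scatter); here the amino leaves altogether and a phenyl enters, so that step is only a loose guide. Compound 3 is therefore expected to shift by about a 1.2-fold higher number from compound 1 to compound 3 (0.08 log units; within the scatter). Compound 3 is estimated at 60000 nM, in the range 15000 nM to 160000 nM.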

Compound 3, half-maximal inhibitory concentration: 17300 nM
Beside the measured number, compound 3's estimate is 3.5-fold (0.54 log units) above it, within the range that was stated.
By their numbers in this assay, from the lowest: compound 3; then compound 1; then compound 2.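

At this saturated chain carbon bound to an amide-type nitrogen, this assay now shows that the chain need not end in an amino or hydroxy group to give a low number. Phenyl in place of aminomethyl gives a 2.9-fold lower number from compound 1 to compound 3 (0.46 log units; beyond the scatter), and phenyl in place of hydroxymethyl gives a 7.4-fold lower number from compound 2 to compound 3 (0.87 log units; beyond the scatter), so compound 3 has the lowest number of the three. No measurement shown accounts for this shift. The compounds shown leave open whether the aromatic ring itself matters, which a cyclohexyl group in place of phenyl would test. They also leave open how a fluorophenyl group or a longer chain carrying the phenyl would read.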